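A few compounds are considered here, and "the series" means these few. Any claim that something is new, unique, unknown or untested is made for them only; others in the source may bear on it.

In a functional assay on L1210 cells (Mus musculus) for inhibition (a lower number here means a stronger inhibitor, a higher number a weaker inhibitor), compound 1 `C=C1[C@@H](O)[C@H](n2cnc3c(S)nc(N)nc32)O[C@@H]1CO` gives 207000 nM and compound 2 `C=C1[C@H](n2cnc3c(N)nc(N)nc32)O[C@H](CO)[C@H]1O` gives 8200 nM. Compound 2 therefore has the lower number of the two and is the stronger inhibitor, and the gap between them lies beyond the usual scatter of repeated measurements. Two values make a very short record, however, and they cannot show a trend.

The next compound to consider is compound 3 `C=C1[C@H](n2cnc3c(SC)nc(N)nc32)O[C@H](CO)[C@H]1O`, which has not yet been measured. It keeps the framework of compound 2 but carries methylsulfanyl in place of amino on an aromatic carbon. The swap sits on a six-membered aromatic ring with 2 nitrogen, and a second amino group on that ring stays in place.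

Within the data shown here, no measured pair of compounds shows this exchange, so its effect here has to be judged without a direct precedent, and the uncertainty is wide. A move toward weaker inhibition, beyond the scatter, is expected, and the estimated step is a 3.7-fold higher number from compound 2 to compound 3 (0.56 log units; beyond the scatter). For compound 3 the expected value is 30000 nM, with an estimated range from 8000 nM to 120000 nM.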

Compound 3, half-maximal inhibitory concentration: > 500000 nM
Compound 3: no number, only a limit (the forecaster's own chance of this, stated with the estimate: 15%); middle value at least 16-fold (1.22 log units) from the limit.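

Among these compounds, putting methylsulfanyl in place of amino on this aromatic carbon, next to the ring nitrogen, gives an at least 60-fold higher number from compound 2 to compound 3 (1.78 log units; beyond the scatter), the first direct reading of what this position contributes, since the two compounds differ in this one place. In this assay compound 3 gives > 500000 nM, which is a limit of the assay and not a number. The full size of the step therefore stays unknown, and only its minimum can be read, because the value of compound 3 lies at that limit: the limit of > 500000 nM in this assay, at which 1 of the 3 values shown sits.

Among the compounds shown here, the single exchange changes several things at once, since amino brings a hydrogen-bond donor, methylsulfanyl brings none, and the heavy atoms differ, so these compounds cannot show which of those differences matters for the loss of inhibition. As far as these compounds go, how a methylamino group, which keeps a nitrogen at this carbon, or a methoxy group, which places an oxygen there, would read in this assay remains open, and either result would help separate those possibilities.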